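Chain extension on the core of compound 2

The source may report more compounds than this note shows. Statements on the series, on what has been measured and on what is new or still open speak of the compounds shown alone.

Compound 2 `Cc1ncc2cnnc(O)n12` is one of three measured members of the series. In a functional assay for inhibition, with Homo sapiens as the target (on this read-out higher numbers stand for weaker inhibition and lower numbers for stronger inhibition), compound 2 gives > 48000 nM, which is a limit of the assay and not a number. Compound 3 `Cc1ncc2cnnc(S)n12` in this assay gives > 48000 nM, likewise a limit. Compound 1 `C=CCSc1nncc2cnc(C)n12` in this assay gives 61000 nM. The measured steps a step that the limit leaves unreadable from compound 1 to compound 2, a step that the limit leaves unreadable from compound 1 to compound 3 and a step that the two limits leave unreadable from compound 2 to compound 3 are each unreadable because of the limit of > 48000 nM in this assay, at which 2 of the 3 values shown sit. Compound 4 `CCCc1ncc2cnnc(O)n12` differs from compound 2 by ethyl in place of hydrogen on a saturated chain carbon bound to an aromatic carbon. Within the data shown here, no measured step touches this chain, so no direction can be drawn from the data, and the weak inhibition seen throughout the series is the only guide. Compound 4 is therefore expected to be weak as well, with 60000 nM estimated in the range 20000 nM to 200000 nM. The step that the limit leaves unreadable from compound 2 to compound 4 is expected to be small.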

Compound 4, half-maximal inhibitory concentration: > 48000 nM
Compound 4: only a limit was reported; the forecaster's own chance of this, stated with the estimate: 60%; the middle value does not contradict the limit.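

Compound 2 and compound 4 both sit at a limit, so no step between them can be read: the limit of > 48000 nM in this assay, at which 3 of the 4 values shown sit.

The compounds shown leave open whether any change on the shared core gives stronger inhibition in this assay.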